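Chloro on the aryl core: expectation for compound 4

A few compounds are considered here, and "the series" means these few. Any claim that something is new, unique, unknown or untested is made for them only; others in the source may bear on it.

Three analogues on a shared core have been measured so far. In an assay on isolated protein for inhibition of Dihydrofolate reductase (Mus musculus) (on this read-out lower numbers stand for lower potency and higher numbers for higher potency (the scale is a negative logarithm)), compound 1 `CC1(C)N=C(N)N=C(N)N1c1ccc(OCc2cccc(Cl)c2S(=O)(=O)F)c(Cl)c1` gives 7.42, compound 2 `CC1(C)N=C(N)N=C(N)N1c1cccc(OCCCCOc2ccc(S(=O)(=O)F)cc2)c1` gives 7.49, and compound 3 `CC1(C)N=C(N)N=C(N)N1c1ccc(OCc2ccccc2S(=O)(=O)F)c(Cl)c1` gives 7.43; all three lie within the scatter of one another. Within the data shown here, the only change so far made in one place, (chloro in place of hydrogen on an aromatic carbon), gives a number 0.01 log units lower from compound 3 to compound 1 (within the scatter). Compound 4 `CC1(C)N=C(N)N=C(N)N1c1ccc(Cl)c(OCCCCOc2ccc(S(=O)(=O)F)cc2)c1` awaits measurement. It differs from compound 2 by chloro in place of hydrogen on an aromatic carbon; the difference between the cores of compound 2 and compound 3 is not broken down here. The chloro of compound 1 sits ortho to a fluorosulfonyl group and meta to a large group, whereas in compound 4 it sits ortho to a large group and para to a large group, so this is the same kind of change, not the same one. The expected step is a number 0.01 log units higher from compound 2 to compound 4 (within the scatter), resting on the earlier a number 0.01 log units lower from compound 3 to compound 1 (within the scatter). Compound 4 is therefore estimated at 7.5, between 7.1 and 7.9.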

Compound 4, logarithm of the reciprocal of the active concentration, log(1/C): 7.17
Beside the measured number, compound 4's estimate is 0.33 log units above it; measured number inside the range.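

In this assay, chloro in place of hydrogen on an aromatic carbon, here ortho to a large group and para to a large group, gives a number 0.32 log units lower from compound 2 to compound 4 (beyond the scatter). Set beside the earlier step, the two results do not separate: the same change on two cores in this assay, a number 0.01 log units lower (within the scatter) from compound 3 to compound 1 and a number 0.32 log units lower (beyond the scatter) from compound 2 to compound 4, 0.31 log units apart, within the scatter of two such steps. This gives no ground for calling the change dependent on the core, but two pairs also do not establish a step that carries over unchanged, and the chloro does not occupy the same place in both.

On these data alone, whether fluoro, methyl or methoxy at this place on the core of compound 2 gives a step of similar size remains open. So does the result of chloro on a core with a longer chain.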